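The source may report more compounds than this note shows. Statements on the series, on what has been measured and on what is new or still open speak of the compounds shown alone.

Of the compounds shown here, three built on one shared core have been measured in a functional assay (blood) for inhibition, with Homo sapiens as the target; on this read-out higher numbers stand for weaker inhibition and lower numbers for stronger inhibition. Compound 1 `C/C(=N\OCCSc1nnnn1C)c1ccc(Sc2cc(F)cc(C3CCOCC3)c2)cc1` gives 120 nM in this assay. Compound 2 `C/C(=N\OC(=O)C(C)(C)C)c1ccc(Sc2cc(F)cc(C3CCOCC3)c2)cc1` gives 40 nM, the lowest of the three numbers. Compound 3 `CS/C(=N\O)c1ccc(Sc2cc(F)cc(C3CCOCC3)c2)cc1` gives 190 nM. Two steps link them: a 3.0-fold lower number from compound 1 to compound 2 (0.48 log units; beyond the scatter), and a 4.8-fold higher number from compound 2 to compound 3 (0.68 log units; beyond the scatter). Compound 4 `CCOC(=O)c1csc(CO/N=C(\C)c2ccc(Sc3cc(F)cc(C4CCOCC4)c3)cc2)n1` has not yet been measured. It differs from compound 2 in one place: (4-(ethoxycarbonyl)-1,3-thiazol-2-yl)methyl in place of (tert-butyl)carbonyl on an oxygen. The step from compound 1 to compound 2 bears on this change, since it also exchanged the group on an oxygen, and there the 2-((1-methyl-1H-tetrazol-5-yl)sulfanyl)ethyl group went with the higher number and the (tert-butyl)carbonyl with the lower. Compound 4 once more carries a larger group with a ring on that oxygen, so a modest step toward a higher number in this assay is expected, of about the size seen between compound 1 and compound 2, rather than a fall or no change beyond the scatter. Compound 4 is therefore expected to give 120 nM in this assay, within a range of 50 nM to 300 nM. This estimate means an expected step of a 3.0-fold higher number from compound 2 to compound 4 (0.48 log units; beyond the scatter).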

Compound 4, half-maximal inhibitory concentration: 150 nM
Estimate against measurement, compound 4: 1.3-fold (0.10 log units) below, and the stated range covers the measured number.
By their numbers in this assay, from the lowest: compound 2; then compounds 1, 4 and 3 (each within the scatter of the next).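

In this assay, putting the (4-(ethoxycarbonyl)-1,3-thiazol-2-yl)methyl group on this oxygen in place of the (tert-butyl)carbonyl group gives a 3.8-fold higher number from compound 2 to compound 4 (0.57 log units; beyond the scatter) and so adds a second, different group that goes with a higher number than the (tert-butyl)carbonyl. The two larger ring-bearing groups cannot be told apart here, since a 1.3-fold higher number from compound 1 to compound 4 (0.10 log units; within the scatter) is a step within the scatter, even though one carries a five-membered aromatic ring with an ester and the other a tetrazole on a sulfur-containing chain. No measured evidence explains why the (tert-butyl)carbonyl group stands apart from these two.

An acetyl group on the same oxygen could help show whether the lower number follows the carbonyl or the tert-butyl part. A carboxylic acid in place of the ethoxycarbonyl would test whether the ester matters on the ring.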